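A few compounds are considered here, and "the series" means these few. Any claim that something is new, unique, unknown or untested is made for them only; others in the source may bear on it.

Of the compounds shown here, three sharing one core have been measured in a functional assay on liver (Sus scrofa) for inhibition of squalene monooxygenase (Homo sapiens), using microsomes; on this read-out higher numbers stand for weaker inhibition and lower numbers for stronger inhibition. Compound 1 `CCN(C/C=C/C#CC(C)(C)C)Cc1cccc(OC[Si](C)(C)c2ccc(Cl)cc2)c1` carries a 4-chlorophenyl on the silicon and gives 400 nM. Compound 2 `CCN(C/C=C/C#CC(C)(C)C)Cc1cccc(OC[Si](C)(C)c2ccccc2C(F)(F)F)c1`, with 2-(trifluoromethyl)phenyl in that place, gives 70 nM, the lowest of the three numbers and so the strongest inhibition seen. Compound 3 `CCN(C/C=C/C#CC(C)(C)C)Cc1cccc(OC[Si](C)(C)c2ccc(C(=O)C(F)(F)F)cc2)c1`, with 4-((trifluoromethyl)carbonyl)phenyl on the silicon, gives 5000 nM. The steps between them are a 5.7-fold lower number from compound 1 to compound 2 (0.76 log units; beyond the scatter), a 13-fold higher number from compound 1 to compound 3 (1.10 log units; beyond the scatter) and a 71-fold higher number from compound 2 to compound 3 (1.85 log units; beyond the scatter), so the group on the silicon plainly matters, and compound 2 stands nearest to compound 1 and furthest from compound 3.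

Compound 4 `CCN(C/C=C/C#CC(C)(C)C)Cc1cccc(OC[Si](C)(C)C2CCCCC2)c1` has not yet been measured. It differs from compound 2 in one place: cyclohexyl in place of 2-(trifluoromethyl)phenyl on a silicon. Every measured step swaps one aromatic ring for another, and none swaps an aromatic ring for a non-aromatic one, so they bear on this change only loosely; they do show that the group on the silicon can shift this assay by a modest to large amount in either direction. With cyclohexyl entering where 2-(trifluoromethyl)phenyl leaves, compound 4 is expected to inhibit less strongly than compound 2, a step of a 5.7-fold higher number from compound 2 to compound 4 (0.76 log units; beyond the scatter). Compound 4 is therefore estimated at 400 nM, with a range from 100 nM to 2000 nM.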

Compound 4, half-maximal inhibitory concentration: 20000 nM
Beside the measured number, compound 4's estimate is 50-fold (1.70 log units) below it; measured number above the stated range.
By their numbers in this assay, from the lowest: compound 2; then compound 1; then compound 3; then compound 4.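

In this assay, putting the non-aromatic cyclohexyl on the silicon gives the weakest inhibition of the four compounds, whichever aromatic ring it replaces: (a 290-fold higher number from compound 2 to compound 4 (2.46 log units; beyond the scatter)), (a 50-fold higher number from compound 1 to compound 4 (1.70 log units; beyond the scatter)) and (a 4.0-fold higher number from compound 3 to compound 4 (0.60 log units; beyond the scatter)). The earlier steps shown here showed only how far one aromatic ring could differ from another, whereas this result puts all three aromatic compounds on the stronger side of cyclohexyl, including compound 3, which had the highest number until now. A six-membered ring of carbon on the silicon is therefore not enough on its own to keep the inhibition of compound 2, and nothing available here explains the loss.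

Cyclohexyl differs from 2-(trifluoromethyl)phenyl both in having a non-aromatic ring and in lacking the trifluoromethyl group and its fluorine atoms, so the contribution of each change remains open. An unsubstituted phenyl or a 2-(trifluoromethyl)cyclohexyl on the silicon would help separate the two, while cyclopentyl or an open hexyl chain would show how other non-aromatic groups fare at this position.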